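Benzothiazole thioacetamide series: notes toward compound 4

This account rests on a few compounds, and the source may have more. Where it says the series, first, only, none or still open, it means among the compounds named here.

Measured compounds, with their result in a functional assay on MGC-803 cells (Homo sapiens) for antiproliferative activity, read by MTT assay, with a stated time of 48 h; a lower number here means a stronger inhibitor, a higher number a weaker inhibitor:
- compound 1 `COc1ccc(CN(C(=O)CSc2nc3cc(Br)ccc3s2)c2cc(OC)c(OC)c(OC)c2)cc1O`: 372 nM
- compound 2 `COc1ccc(CN(C(=O)CSc2nc3ccccc3s2)c2cc(OC)c(OC)c(OC)c2)cc1N`: 84 nM
- compound 3 `COc1ccc(CN(C(=O)CSc2nc3c(C)cccc3s2)c2cc(OC)c(OC)c(OC)c2)cc1O`: 493 nM

Compound 2 stands lowest of the three in this assay; compound 1 and compound 3 both lie beyond the scatter from it, so compound 2 is the most potent of the measured set. Among the compounds with values here, the only one-place step measured, a 1.3-fold higher number from compound 1 to compound 3 (0.12 log units; within the scatter), concerns a group on a sulfur and lies within the scatter.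

Compound 4 `COc1cc(N(Cc2ccc(Cl)cc2)C(=O)CSc2nc3ccccc3s2)cc(OC)c1OC` differs from compound 2 in another place: 4-chlorophenyl in place of 3-amino-4-methoxyphenyl on a saturated chain carbon bound to an amide-type nitrogen. Within the data shown here, no measured step touches this position; compound 1 and compound 3 differ from compound 2 in two places at once, so their values show only that the set is sensitive to changes on the 3-substituted-4-methoxyphenyl ring and its neighbours. With the amino group and methoxy group leaving and a 4-chlorophenyl entering, the expectation is a weaker inhibitor, estimated as a 4.2-fold higher number from compound 2 to compound 4 (0.62 log units; beyond the scatter). Compound 4 is therefore estimated at 350 nM, within a range from 80 nM to 1500 nM.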

Compound 4, half-maximal inhibitory concentration: > 80000 nM
Compound 4: no number, only a limit; the forecaster's own chance of this, stated with the estimate: 5%; middle value at least 220-fold (2.35 log units) from the limit.
By their numbers in this assay, from the lowest: compound 2; then compounds 1 and 3 (each within the scatter of the next). At a limit, above all of these: compound 4.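

In this assay compound 4 has only a limit, not a number: the limit of > 80000 nM in this assay, at which 1 of the 4 values shown sits. Within the data shown here, the group on a saturated chain carbon bound to an amide-type nitrogen therefore carries far more weight than the only earlier one-place step suggested: 3-amino-4-methoxybenzyl to 4-chlorobenzyl gives an at least 950-fold higher number from compound 2 to compound 4 (2.97 log units; beyond the scatter), whereas the change on a sulfur gives a 1.3-fold higher number from compound 1 to compound 3 (0.12 log units; within the scatter). A six-membered aromatic ring of carbon only stands at this place on both sides of the step, so the presence of that ring alone does not preserve the activity of compound 2.

The amino group and the methoxy group leave and the chlorine enters in one step, so the compounds shown do not assign the loss to any one of them. From the compounds shown here alone, whether an unsubstituted phenyl or a 4-aminophenyl at this place would read like compound 2 or like compound 4 also remains open.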